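Phenylethynyl for Nitro on a Deoxyuridine Scaffold

The compounds below may be only part of what the source reports. "The series", "measured", "known", "first", "only" and "open" are said of these compounds alone.

Measured so far:
compound 1 `OC[C@H]1C[C@@H](Cn2cnc3c(-c4ccccc4)ncnc32)c2ccccc21` gives 28100 nM
compound 2 `O=c1[nH]c(=O)n([C@H]2C[C@H](O)[C@@H](CO)O2)cc1[N+](=O)[O-]` gives 130 nM
compound 3 `C[C@H](O)C1CC(Cn2cnc3c(N)ncnc32)C1(C)C` gives > 200000 nM

In an ADME assay on L1210/0 cells (Mus musculus) for cytotoxicity, with a stated time of 48 h (on this read-out lower numbers stand for stronger inhibition and higher numbers for weaker inhibition), compound 2 gives 130 nM, the lower of the two numbers reported, while compound 1 gives 28100 nM, a gap beyond the usual scatter. Compound 3 reaches only a limit of the assay, > 200000 nM, and no number is known for it; this is the limit described in the limit of > 200000 nM in this assay, at which 1 of the 3 values shown sits.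

Compound 4 `O=c1[nH]c(=O)n([C@H]2C[C@H](O)[C@@H](CO)O2)cc1C#Cc1ccccc1` has not yet been measured. It differs from compound 2 in one place: 2-phenylethynyl in place of nitro on an aromatic carbon. Going by the values given here, no step between two measured compounds describes such a change, so the expected size of the step from compound 2 to compound 4 in this assay rests on compound 2 alone and on the replacement of a small polar group by a large hydrocarbon one. The account expects the number for compound 4 to rise, that is, weaker inhibition, by a step estimated as a 77-fold higher number from compound 2 to compound 4 (1.89 log units; beyond the scatter). The value for compound 4 is estimated at 10000 nM, with a range from 1000 nM to 100000 nM.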

Compound 4, half-maximal inhibitory concentration: > 200000 nM
Compound 4 was reported as a limit; the forecaster's own chance of this, stated with the estimate: 15%; middle value at least 20-fold (1.30 log units) from the limit.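

The earlier compounds shown here said nothing about this aromatic carbon, ortho to a group of 1 heavy atom on the shared core. Here, 2-phenylethynyl in place of nitro in this assay brings an at least 1500-fold higher number from compound 2 to compound 4 (3.18 log units; beyond the scatter), so this one place alone decides whether the core gives a measurable number in this assay. Compound 4 gives > 200000 nM, which is a limit of the assay and not a number, and it joins the values held at that limit: the limit of > 200000 nM in this assay, at which 2 of the 4 values shown sit.

One step cannot tell whether the change in read-out belongs to the departure of nitro or to the arrival of 2-phenylethynyl. An amine, a carboxylic acid or a plain ethynyl group at this carbon would be needed to separate the two readings.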